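Step to trifluoromethyl analogue in the shared core series

A few compounds are considered here, and "the series" means these few. Any claim that something is new, unique, unknown or untested is made for them only; others in the source may bear on it.

Measured so far:
compound 1 `Cn1nc2c(=O)n(CC3(O)CCN(Cc4ccc(-c5ccco5)cc4Cl)CC3)cnc2c1-c1ccc(Cl)cc1` — 143 nM
compound 2 `Cn1nc2c(=O)n(CC3(O)CCN(Cc4ccc(-c5ccco5)cc4Cl)CC3)cnc2c1-c1ccc(CNS(C)(=O)=O)cc1` — 65.3 nM

In an assay on isolated protein for inhibition of ubiquitin carboxyl-terminal hydrolase 7 (Homo sapiens), with stated times of 30 min and 2 h (a lower number here means a stronger inhibitor, a higher number a weaker inhibitor), compound 2 gives the lowest of the two numbers; its nearest neighbour is compound 1, and the step of a 2.2-fold lower number from compound 1 to compound 2 (0.34 log units; beyond the scatter) is modest but beyond the scatter. Compound 3 `Cn1nc2c(=O)n(CC3(O)CCN(Cc4ccc(-c5ccco5)cc4Cl)CC3)cnc2c1-c1ccc(C(F)(F)F)cc1` is not yet measured. It differs from compound 2 by trifluoromethyl in place of (methanesulfonamido)methyl on an aromatic carbon, at the same place as the change from compound 1 to compound 2. Among the compounds with values here, only that step bears on it; the group entering here carries no donor or acceptor, as with the chloro of compound 1. A modest rise is therefore expected, roughly undoing that step. Compound 3 is estimated at 130 nM, range 55 nM to 310 nM, expected step a 2.0-fold higher number from compound 2 to compound 3 (0.30 log units; within the scatter).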

Compound 3, half-maximal inhibitory concentration: 530 nM
Compound 3: the middle estimate sits 4.1-fold (0.61 log units) below what was measured; the whole stated range lies below it.
By their numbers in this assay, from the lowest: compound 2; then compound 1; then compound 3.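

With an 8.1-fold higher number from compound 2 to compound 3 (0.91 log units; beyond the scatter) in this assay this position spans a wider range than compound 1 and compound 2 alone showed. Trifluoromethyl and chloro, neither carrying a hydrogen-bond donor or acceptor, are not interchangeable here, as a 3.7-fold higher number from compound 1 to compound 3 (0.57 log units; beyond the scatter) shows. No measurement is available that accounts for this order among the three groups.

Still open, as far as these compounds go, is whether compound 2 owes its lower number to the whole (methanesulfonamido)methyl group or to only part of it. An aminomethyl, a methyl sulfone or a nitrile at the same place on the shared core would address this.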